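The compounds below may be only part of what the source reports. "The series", "measured", "known", "first", "only" and "open" are said of these compounds alone.

Of the compounds shown here, three have been tested so far in a functional assay on NCI-H460 cells (Homo sapiens) for inhibition, read by MTT assay, with a stated time of 24 h, tested at 0.1 ug/mL (a lower number here means less inhibition of growth, a higher number more inhibition of growth at the concentration tested), at a single concentration. Compound 1 (`O=C(O)CCCCC(CCSC(=O)c1ccccc1)SC(=O)c1ccccc1`) reads "not active" (no number reported) in that measurement, and compound 2 (`O=C(CCCCC(S)CCS)Nc1ccccc1Cl`) reads 6.36% in the same measurement. Compound 3 (`O=C(CCCCC(S)CCS)Nc1ccc(Cl)cc1`) reads "not active" (no number reported) and so has no single number, and one further entry also lacks one. Compound 4 (`O=C(CCCCC(S)CCS)Nc1ccc([N+](=O)[O-])cc1`) has not yet been measured. The structural change is nitro in place of chloro on an aromatic carbon and it sits para to a large group. Within the data shown here, no measured step covers this change, and no step beyond the scatter is expected in this assay in either direction. Compound 4 is estimated at 5% with an expected range from 0% to 18% in this reading.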

Compound 4, percent growth inhibition at one concentration: 5.69%
For compound 4 the middle estimate is 0.7 percentage points below the measured one; the measured number falls inside the stated range.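

In this assay, among these compounds, compound 3 reads "not active" (no number reported) and compound 4 reads 5.69%, so no step between them can be read. The compounds shown leave open what nitro in place of chloro does to growth inhibition, and no evidence here bears on this result.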